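Aryl substituent variation in the shared core

This account rests on a few compounds, and the source may have more. Where it says the series, first, only, none or still open, it means among the compounds named here.

compound 1 `Cc1cc(-c2sc(Cc3cccc(C(F)(F)F)c3)nc2C)ccc1C(N)=O`: 73 nM
compound 2 `COc1cccc(Cc2nc(C)c(-c3ccc(C(N)=O)c(C)c3)s2)c1`: 160 nM
compound 3 `Cc1cc(-c2sc(Cc3cccc(N(C)C)c3)nc2C)ccc1C(N)=O`: 690 nM

In a functional assay on cells for agonist activity at G-protein coupled receptor 52 (Homo sapiens), read by AlphaScreen and cAMP accumulation, with a stated time of 30 min (on this read-out higher numbers stand for an effect only at larger amounts of compound and lower numbers for an effect already at smaller amounts), compound 3 stands highest of the three measured compounds: a 9.5-fold higher number from compound 1 to compound 3 (0.98 log units; beyond the scatter) and a 4.3-fold higher number from compound 2 to compound 3 (0.63 log units; beyond the scatter), both beyond the scatter. Compound 4 `Cc1cc(-c2sc(Cc3cccc(F)c3)nc2C)ccc1C(N)=O` differs from compound 3 by fluoro in place of dimethylamino on an aromatic carbon. Among the measured compounds shown here, no measured step introduces fluoro, so the two steps that bear on it are those in which dimethylamino is exchanged, and both run toward lower numbers when dimethylamino leaves. A lower number than that of compound 3 is therefore expected for compound 4, of a size comparable to the methoxy step. For compound 4 the estimate in this assay is 180 nM with a range from 60 nM to 550 nM. The expected step is a 3.8-fold lower number from compound 3 to compound 4 (0.58 log units; beyond the scatter).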

Compound 4, half-maximal effective concentration: 260 nM
For compound 4 the middle estimate is 1.4-fold (0.16 log units) below the measured one, and the stated range covers the measured number.
By their numbers in this assay, from the lowest: compound 1; then compounds 2 and 4 (each within the scatter of the next); then compound 3.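

In this assay, a single fluoro at this place, on the aromatic carbon meta to a large group, also gives a lower number than dimethylamino, with a 2.7-fold lower number from compound 3 to compound 4 (0.42 log units; beyond the scatter), so compound 3 remains highest of the four. Fluoro and methoxy are not separated, with a 1.6-fold higher number from compound 2 to compound 4 (0.21 log units; within the scatter), whereas trifluoromethyl keeps the lowest number, with a 3.6-fold higher number from compound 1 to compound 4 (0.55 log units; beyond the scatter) in this comparison. No available evidence bears on the reason for this order. Still open, from the compounds shown here alone, is how a carboxylic acid, a primary amine or chloro would rank at this place.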